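Amide aryl trimming in a bis-benzylidene piperidinone series

This account rests on a few compounds, and the source may have more. Where it says the series, first, only, none or still open, it means among the compounds named here.

Compound 3 `Cc1ccc(NC(=O)/C=C/C(=O)N2C/C(=C\c3ccccc3)C(=O)/C(=C/c3ccccc3)C2)cc1C` gives 31000 nM in a functional assay on L1210 cells (Mus musculus) for cytotoxicity (on this read-out lower numbers stand for stronger inhibition and higher numbers for weaker inhibition), the highest number of the three measured. Compound 1 `Cc1cccc(C)c1NC(=O)/C=C/C(=O)N1C/C(=C\c2ccccc2)C(=O)/C(=C/c2ccccc2)C1` gives 22000 nM and compound 2 `Cc1ccc(NC(=O)/C=C/C(=O)N2C/C(=C\c3ccccc3)C(=O)/C(=C/c3ccccc3)C2)cc1` gives 5800 nM in this assay. Compound 4 `O=C(/C=C/C(=O)N1C/C(=C\c2ccccc2)C(=O)/C(=C/c2ccccc2)C1)Nc1ccccc1` is not yet measured; it differs from compound 3 by phenyl in place of 3,4-dimethylphenyl on an amide-type nitrogen. Going by the values given here, two steps bear on this. The step of a 5.3-fold higher number from compound 2 to compound 3 (0.73 log units; beyond the scatter) shows that adding a methyl to the aryl raised the number. The step of a 3.8-fold lower number from compound 1 to compound 2 (0.58 log units; beyond the scatter) also favours the less substituted aryl, while a 1.4-fold higher number from compound 1 to compound 3 (0.15 log units; within the scatter) stays within the scatter. Removing both methyls is therefore expected to lower the number, roughly to the level of compound 2, giving an expected 3.9-fold lower number from compound 3 to compound 4 (0.59 log units; beyond the scatter). Compound 4 is expected at 8000 nM, within 2500 nM to 25000 nM.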

Compound 4, half-maximal inhibitory concentration: 3600 nM
Compound 4: middle estimate off by 2.2-fold (0.35 log units), on the high side; the range from low to high includes it.
By their numbers in this assay, from the lowest: compounds 4 and 2 (each within the scatter of the next); then compounds 1 and 3 (each within the scatter of the next).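

Going down to unsubstituted phenyl on the amide nitrogen gives an 8.6-fold lower number from compound 3 to compound 4 (0.94 log units; beyond the scatter) in this assay and also a 6.1-fold lower number from compound 1 to compound 4 (0.79 log units; beyond the scatter), so both dimethylphenyl compounds sit clearly on the weaker side of the parent anilide. Going by these compounds alone, the single methyl of compound 2 makes no readable difference, with a 1.6-fold lower number from compound 2 to compound 4 (0.21 log units; within the scatter), so only the two dimethylphenyl groups stand apart from phenyl here. Nothing at hand accounts for this pattern.

Still open, going by these compounds, is whether the aryl tolerates anything other than methyl, such as chlorine, methoxy, an amine or a carboxylic acid.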